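Swapping the Urea Aryl Group Toward a Trifluoromethylphenyl

A few compounds are considered here, and "the series" means these few. Any claim that something is new, unique, unknown or untested is made for them only; others in the source may bear on it.

Two related compounds have been tested in a functional assay on OVCAR-3 cells (Homo sapiens) for inhibition, read by sulforhodamine B assay, with a stated time of 48 h, tested at 100 uM; on this read-out higher numbers stand for a weaker effect at the one concentration tested and lower numbers for a stronger effect. Compound 1 `COc1cc(Cl)cc(-c2nn(-c3cccc(NC(=O)Nc4cc(C(F)(F)F)cc(C(F)(F)F)c4)c3)cc2-c2ccncc2)c1` gives -81%, while compound 2 `COc1cc(Cl)cc(-c2nn(-c3cccc(NC(=O)Nc4ccc(Cl)c(Cl)c4)c3)cc2-c2ccncc2)c1` gives -4%. Going by the values given here, compound 2 stands highest of the two numbers, and its only neighbour, compound 1, lies lower by a gap beyond the usual scatter.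

Compound 3 `COc1cc(Cl)cc(-c2nn(-c3cccc(NC(=O)Nc4cccc(C(F)(F)F)c4)c3)cc2-c2ccncc2)c1` has not yet been measured. It differs from compound 2 by 3-(trifluoromethyl)phenyl in place of 3,4-dichlorophenyl on an amide-type nitrogen. Among the compounds with values here, no measured pair shows this exact change, so the size of the step is uncertain. A downward step, toward a stronger effect, is expected, with a number 36 percentage points lower from compound 2 to compound 3 (beyond the scatter) as the estimated change, partly because compound 1 gives -81%. Compound 3 is therefore estimated at -40%, in a range from -80% to 5%.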

Compound 3, a percentage reported as activity, at one concentration (the size of the read-out at that concentration, not a potency): -41%
Compound 3: middle estimate off by 1 percentage points, on the high side; measured number inside the range.
By their numbers in this assay, from the lowest: compound 1; then compound 3; then compound 2.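

In this assay, the aryl group on the amide-type nitrogen clearly matters: 3-(trifluoromethyl)phenyl in place of 3,4-dichlorophenyl gives a number 37 percentage points lower from compound 2 to compound 3 (beyond the scatter), a stronger effect. One trifluoromethyl group is not the whole story, as hydrogen in place of the other trifluoromethyl gives a number 40 percentage points higher from compound 1 to compound 3 (beyond the scatter), a weaker effect. Across these compounds, then, the trifluoromethyl groups track with the stronger effect. Going by these compounds, whether a nitrile or an amine on that ring, in place of trifluoromethyl, would keep the effect remains open. Nothing available explains why these changes act as they do.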